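Ethyl for tert-butyl on the ring nitrogen of a phthalazinone

The compounds below may be only part of what the source reports. "The series", "measured", "known", "first", "only" and "open" are said of these compounds alone.

Measured compounds:
compound 1, `COc1ccc(Cc2nn(C(C)(C)C)c(=O)c3ccccc23)cc1OC`, 10000 nM
compound 2, `Cn1nc(Cc2ccc(Cl)c(Cl)c2)c2ccccc2c1=O`, 4900 nM

Both compounds were tested in a functional assay on aorta with Alpha-1D adrenergic receptor (Rattus norvegicus) as the target; on this read-out higher numbers stand for an effect only at larger amounts of compound and lower numbers for an effect already at smaller amounts. Compound 1 gives 10000 nM, the highest of the two numbers. Compound 2 gives 4900 nM, a number lower by a margin beyond the usual scatter, so compound 2 acts at smaller amounts than compound 1. Compound 2 differs from compound 1 in more than one place, so no single cause for that gap can be named.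

Compound 3, `CCn1nc(Cc2ccc(OC)c(OC)c2)c2ccccc2c1=O`, keeps the dimethoxybenzyl part and the core of compound 1 and changes one thing: ethyl in place of tert-butyl on an aromatic nitrogen. No single-point step of this kind has been measured among the compounds shown, so the expectation rests only on the two numbers above. The lower number of compound 2, which also carries a short group on that ring nitrogen, suggests that a move away from tert-butyl is unlikely to make the number worse. The step of a 1.7-fold lower number from compound 1 to compound 3 (0.22 log units; within the scatter) is expected to be modest and downward, close to the scatter. Compound 3 is therefore estimated at 6000 nM, with a range from 2000 nM to 20000 nM.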

Compound 3, half-maximal effective concentration: 5300 nM
For compound 3 the middle estimate is 1.1-fold (0.05 log units) above the measured one, and the stated range covers the measured number.
By their numbers in this assay, from the lowest: compounds 2, 3 and 1 (each within the scatter of the next, the first and the last beyond it).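

Until now the two measured compounds differed in more than one place, so nothing could be said about the group on the aromatic nitrogen alone. Within the data shown here, the step of a 1.9-fold lower number from compound 1 to compound 3 (0.28 log units; within the scatter) in this assay isolates that group for the first time, with the dimethoxybenzyl part and the core of compound 1 held fixed, and it shows that replacing tert-butyl, with 4 heavy atoms, by ethyl, with 2 heavy atoms, gives a difference that cannot be told apart from the scatter of repeated measurements. Nothing measured here speaks to the reason for this result.

The compounds shown leave open whether a group of a different kind on this nitrogen, such as a longer chain like hexyl, a benzyl ring or a chain ending in an amine or a carboxylic acid, would give a number clearly apart from those of compound 1 and compound 3. On these data alone, it also remains open whether the swap from tert-butyl to ethyl would give a similarly small step with a dichlorobenzyl part in place of the dimethoxybenzyl part.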